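A few compounds are considered here, and "the series" means these few. Any claim that something is new, unique, unknown or untested is made for them only; others in the source may bear on it.

Working notes on the series in a functional assay on RS4-11 cells (Homo sapiens) for inhibition, read by CCK-8 assay, with a stated time of 48 h, tested at 20 uM; a higher number here means more inhibition of growth at the concentration tested, a lower number less inhibition of growth: compound 3 (`N#C/C(=C\c1ccccc1OS(=O)(=O)c1ccc([N+](=O)[O-])cc1)C(=O)Nc1nnc(Cc2ccccc2)s1`) gives 57%, the lowest of three numbers, against compound 1 (`N#C/C(=C\c1ccccc1OS(=O)(=O)c1ccc(F)cc1)C(=O)Nc1nnc(Cc2cccc3ccccc23)s1`) at 68% and compound 2 (`COc1ccc(S(=O)(=O)Oc2ccccc2/C=C(\C#N)C(=O)Nc2nnc(Cc3ccccc3)s2)cc1`) at 78%. Compound 4 (`N#C/C(=C\c1ccccc1OS(=O)(=O)c1ccc(F)cc1)C(=O)Nc1nnc(Cc2ccccc2)s1`) differs from it by fluoro in place of nitro on an aromatic carbon, para to a large group. Going by the values given here, the one measured step at this place is a number 21 percentage points lower from compound 2 to compound 3 (beyond the scatter), a modest drop on introducing nitro in place of methoxy. Compound 1 also carries fluoro at 68%, but differs elsewhere. Losing nitro is therefore expected to give a modest rise in this assay, recovering part of that drop. The expected change is a number 12 percentage points higher from compound 3 to compound 4 (beyond the scatter). For compound 4 the estimated value is 69%, with an expected range of 56% to 82%.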

Compound 4, percent growth inhibition at one concentration: 69%
Estimate against measurement, compound 4: no gap at the digits printed, within the range that was stated.
By their numbers in this assay, from the lowest: compound 3; then compounds 1, 4 and 2 (each within the scatter of the next).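

In this assay the swap from 4-nitrophenyl to 4-fluorophenyl gives a number 12 percentage points higher from compound 3 to compound 4 (beyond the scatter) and the swap from methoxy to fluoro gives a number 9 percentage points lower from compound 2 to compound 4 (within the scatter), so among these three groups at this place only nitro stands apart. Phenyl in place of naphthalen-1-yl gives a number 1 percentage points higher from compound 1 to compound 4 (within the scatter), so with fluoro held fixed this far end of the molecule does not separate the two compounds. No measurement here bears on the reason for either result. Still open, from the compounds shown here alone, is how an amine or a carboxylic acid would read on an aromatic carbon at this same place, and whether naphthalen-1-yl would leave the methoxy or nitro compounds equally unchanged.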